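This account rests on a few compounds, and the source may have more. Where it says the series, first, only, none or still open, it means among the compounds named here.

Compound 1 `Nc1nc(N)c2cc(N(Cc3ccc(OC(F)(F)F)cc3)Cc3ccc(OC(F)(F)F)cc3)ccc2n1` and compound 2 `CN(C)CCCOc1ccc(CNc2ccc3nc(N)nc(N)c3c2)cc1` share a core that carries two amino groups, and each was tested in a physicochemical assay for inhibition, read by spectrophotometry, with a stated time of 10 min; on this read-out lower numbers stand for stronger inhibition and higher numbers for weaker inhibition. In this assay compound 1 gives 33900 nM, the highest of the two numbers shown, while compound 2 gives 6380 nM, a gap that lies beyond the usual scatter of the method. Compound 3 `CCN(Cc1ccc(OC(F)(F)F)cc1)c1ccc2nc(N)nc(N)c2c1` has not yet been measured. It differs from compound 1 in one place: methyl in place of 4-(trifluoromethoxy)phenyl on a saturated chain carbon bound to a nitrogen on an aromatic ring. In plainer terms, one of the two large arms on the nitrogen attached to the core is replaced by a small one. For the measured compounds named here, no step between measured compounds follows this exact change, so the expectation rests on the two values shown. For compound 3 the step from compound 1 is expected to be a 2.3-fold lower number from compound 1 to compound 3 (0.35 log units; beyond the scatter), toward a lower number. Compound 3 is therefore estimated at 15000 nM, within a range from 4000 nM to 50000 nM.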

Compound 3, half-maximal inhibitory concentration: 7360 nM
Estimate against measurement, compound 3: 2.0-fold (0.31 log units) above, and the stated range covers the measured number.
By their numbers in this assay, from the lowest: compounds 2 and 3 (each within the scatter of the next); then compound 1.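

In this assay, exchanging one of the two 4-(trifluoromethoxy)benzyl arms on the nitrogen for ethyl gives a 4.6-fold lower number from compound 1 to compound 3 (0.66 log units; beyond the scatter), a modest step toward stronger inhibition. At this position, then, a group of 1 heavy atom in place of 4-(trifluoromethoxy)phenyl, with its 11 heavy atoms and its aromatic ring, does not cost inhibition, so this second large arm is not needed for the inhibition seen in this test. No measurement shown gives a reason for the shift.

Going by these compounds, whether ethyl is the best choice here remains open, since a longer chain such as propyl, or a chain ending in a carboxylic acid, could move the number in either direction. Also unsettled is how much the remaining 4-(trifluoromethoxy)benzyl arm contributes to the inhibition of compound 3.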